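The compounds below may be only part of what the source reports. "The series", "measured", "known", "first", "only" and "open" are said of these compounds alone.

Measured so far in an assay on isolated protein for inhibition of thyroid hormone receptor alpha (Homo sapiens), read by fluorescence polarization; a lower number here means a stronger inhibitor, a higher number a weaker inhibitor:
Compound 1 `CS(=O)(=O)c1ccc(C(=O)NCCC(=O)N2CCCCC2)cc1[N+](=O)[O-]` returns only a limit, > 60000 nM.
Compound 2 `CS(=O)(=O)c1ccc(C(=O)NCC(=O)N(Cc2ccccc2)Cc2ccccc2)cc1[N+](=O)[O-]` gives 1700 nM.
Compound 3 `CCCN(C(=O)CN(C)C(=O)c1ccc(S(C)(=O)=O)c([N+](=O)[O-])c1)c1ccccc1` returns only a limit, > 60000 nM.

For the measured compounds named here, compound 2 carries the only number in the set; the two other compounds sit at the limit of > 60000 nM in this assay, at which 2 of the 3 values shown sit. Going by the values given here, compound 3 shows no number where compound 2 shows one, but the two differ in more than one place, so no single step connects them and nothing is drawn from that pair beyond what the two values show.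

Compound 4 `CN(CC(=O)N(Cc1ccccc1)Cc1ccccc1)C(=O)c1ccc(S(C)(=O)=O)c([N+](=O)[O-])c1` differs from compound 2 in one place: methyl in place of hydrogen on an amide-type nitrogen. Among the compounds with values here, no measured pair isolates this change, so the size of the step rests on expectation alone. A step toward weaker inhibition, beyond the usual scatter, is expected in this assay: a 3.5-fold higher number from compound 2 to compound 4 (0.55 log units; beyond the scatter). Compound 4 is estimated at 6000 nM. Compound 4 is expected to fall between 1500 nM and 40000 nM, with a fair chance that this assay returns only a limit for it.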

Compound 4, half-maximal inhibitory concentration: > 60000 nM
Compound 4: only a limit was reported; the forecaster's own chance of this, stated with the estimate: 25%; middle value at least 10-fold (1.00 log units) away from the limit.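

In this assay, for the compounds shown here, methyl in place of hydrogen on the amide-type nitrogen gives the first one-place comparison: an at least 35-fold higher number from compound 2 to compound 4 (1.54 log units; beyond the scatter). Going by these compounds alone, at this nitrogen, whose other neighbours are a carbonyl carbon and a saturated chain carbon, one added carbon is enough to take compound 2, the only compound in the set with a number, to a limit in compound 4. The step is only a lower bound because compound 4 returns a limit: the limit of > 60000 nM in this assay, at which 3 of the 4 values shown sit.

One pair cannot show whether the loss follows from the missing amide hydrogen or from the methyl itself. Also open, from the compounds shown here alone, is how this nitrogen responds to other groups, such as ethyl or a longer chain carrying an amine.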